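Halogen swap at the aryl urea: chloro to iodo

A few compounds are considered here, and "the series" means these few. Any claim that something is new, unique, unknown or untested is made for them only; others in the source may bear on it.

Measured compounds:
compound 1 `Cc1cccc(NC(=O)N[C@H](C)c2ccccc2)c1` — 47%
compound 2 `COc1cccc(NC(=O)N[C@H](C)c2ccccc2)c1` — 70%
compound 3 `C[C@@H](NC(=O)Nc1cccc(Cl)c1)c1ccccc1` — 83%

In an ADME assay on the whole organism with Oryza sativa as the target, tested at 10 uM (on this read-out lower numbers stand for a stronger effect and higher numbers for a weaker effect at the one concentration tested), compound 3 gives the highest number of the three, with compound 2 nearest at 70% and compound 1 furthest at 47%; both gaps lie beyond the scatter. The two steps that lead into compound 3 are a number 36 percentage points higher from compound 1 to compound 3 (beyond the scatter) and a number 13 percentage points higher from compound 2 to compound 3 (beyond the scatter), and the third step within the measured set is a number 23 percentage points higher from compound 1 to compound 2 (beyond the scatter).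

Compound 4 `C[C@@H](NC(=O)Nc1cccc(I)c1)c1ccccc1` differs from compound 3 in one place:
iodo in place of chloro on an aromatic carbon

Among the measured compounds shown here, no measured step exchanges one halogen for another; the two steps that place chloro on the aromatic carbon, a number 36 percentage points higher from compound 1 to compound 3 (beyond the scatter) and a number 13 percentage points higher from compound 2 to compound 3 (beyond the scatter), both raise the number, and they are the only guide. Compound 3 already stands high on this read-out, so the room for a further rise in this assay is limited. The expected change from compound 3 to compound 4 is therefore small, at most on the edge of the scatter, and it is estimated as a number 3 percentage points higher from compound 3 to compound 4 (within the scatter). On that basis compound 4 is expected to give about 86% in this assay, within a range from 70% to 98%.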

Compound 4, a percentage reported as activity, at one concentration (the size of the read-out at that concentration, not a potency): 73%
Estimate against measurement, compound 4: 13 percentage points above, within the range that was stated.
By their numbers in this assay, from the lowest: compound 1; then compounds 2, 4 and 3 (each within the scatter of the next, the first and the last beyond it).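

In this assay, the halogen exchange on this aromatic carbon, meta to a large group, reads as a number 10 percentage points lower from compound 3 to compound 4 (within the scatter) and so does not separate iodo from chloro. Iodo is not separated from methoxy either, at a number 3 percentage points higher from compound 2 to compound 4 (within the scatter), although chloro and methoxy are separated (a number 13 percentage points higher from compound 2 to compound 3 (beyond the scatter)), so compound 4 lies within the scatter of two compounds that lie beyond it from each other. Methyl remains distinct from iodo, at a number 26 percentage points higher from compound 1 to compound 4 (beyond the scatter), which makes compound 1 the only compound beyond the scatter from all three others, while no information bears on what lies behind any of these steps.

The compounds shown leave open whether an amine or a carboxylic acid on this aromatic carbon would fall with the methyl of compound 1 or with the other three groups, and where fluoro or bromo would stand among the halogens. They also leave open whether iodo and chloro would remain inseparable on a different carbon of the same ring or with the opposite configuration at the chiral carbon of the shared core.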